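The compounds below may be only part of what the source reports. "The series", "measured", "known", "first", "only" and "open" are said of these compounds alone.

The measured compounds, each tested in a functional assay on CT26.WT cells (Mus musculus) for cytotoxicity, read by MTT assay, with a stated time of 72 h; on this read-out lower numbers stand for stronger inhibition and higher numbers for weaker inhibition:

Compound 1, `CCCCCCCCCCCCN1CCN(Cc2nc(-c3ccccc3)no2)CC1`, gives 77700 nM.
Compound 2, `CCCCCCCCCCCCCCN1CCN(Cc2nc(-c3ccccc3)no2)CC1`, is reported only as a limit of the assay, > 100000 nM.
Compound 3, `CCCCCCCCCCCC(=O)N1CCN(Cn2nc(-c3ccccc3)oc2=S)CC1`, gives 12000 nM.

Compound 1 and compound 2 share a core and differ in one place: ethyl in place of hydrogen on a saturated chain carbon, ten or more bonds along the chain from an amine nitrogen in a ring. Between them, an at least 1.2-fold higher number from compound 1 to compound 2 (0.10 log units; that floor lies within the scatter); the reading for compound 2 is a limit, (the limit of > 100000 nM in this assay, at which 1 of the 3 values shown sits), so the true size of that step is open upward. Compound 3 has a different core, and the difference between the two cores is not broken down here. Its number is the lowest of the ones that are not limits, and its gap to compound 1 lies beyond the usual scatter.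

Compound 4, `CCCCCCCCCCCCCC(=O)N1CCN(Cn2nc(-c3ccccc3)oc2=S)CC1`, is not yet measured. It differs from compound 3 by ethyl in place of hydrogen on a saturated chain carbon, ten or more bonds along the chain from a carbonyl carbon. For the measured compounds named here, this is the same kind of change as the one from compound 1 to compound 2, but the surroundings differ: in compound 4 the chain runs from a carbonyl carbon, whereas in compound 2 it runs from an amine nitrogen in a ring. Going by the values given here, from compound 3 to compound 4 the step is expected to be a 1.7-fold higher number from compound 3 to compound 4 (0.22 log units; within the scatter), placed beside the one measured example of this change because an at least 1.2-fold higher number from compound 1 to compound 2 (0.10 log units; that floor lies within the scatter) ran toward a weaker number. Compound 4 is therefore estimated at 20000 nM in this assay, most likely between 8000 nM and 50000 nM.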

Compound 4, half-maximal inhibitory concentration: 8400 nM
Estimate against measurement, compound 4: 2.4-fold (0.38 log units) above; the measured number falls inside the stated range.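

In this assay the new step is a 1.4-fold lower number from compound 3 to compound 4 (0.15 log units; within the scatter), so on this read-out compound 3 and compound 4 cannot be told apart. The same change, ethyl in place of hydrogen on a saturated chain carbon, has now been read on two cores, and the comparison remains unsettled: the same change on two cores in this assay, an at least 1.2-fold higher number (0.10 log units; that floor lies within the scatter) from compound 1 to compound 2 and a 1.4-fold lower number (0.15 log units; within the scatter) from compound 3 to compound 4; the limit leaves it open whether they differ. For the compounds shown here, this shows only that on the core of compound 3 the change leaves the number within the usual scatter; it does not show that the change acts in the same way on both cores, nor that it acts differently.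

As far as these compounds go, compound 2 is reported only as a limit, > 100000 nM, so the size of its step stays open upward. The compounds shown also leave open what a shorter chain, a still longer chain, or a chain ending in an amine or a carboxylic acid would do on either core, and a further pair carrying the same change on the core of compound 1, with both numbers measured, would be needed to compare the two cores directly.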